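The compounds below may be only part of what the source reports. "The series", "measured", "known", "first", "only" and "open" are said of these compounds alone.

Compound 1 `C/C(=C\C(=O)Nc1ccccc1OCCCC(=O)O)c1ccc2c(ccn2C)c1` — 780 nM
Compound 2 `C/C(=C\C(=O)Nc1ccccc1OCCCC(=O)O)c1ccc2c(ccn2Cc2ccc(C(F)(F)F)cc2)c1` — 300 nM

Both compounds were tested in an assay on Prostate gland for inhibition of steroid 5-alpha-reductase (Rattus norvegicus); on this read-out higher numbers stand for weaker inhibition and lower numbers for stronger inhibition. Among the two numbers so far, compound 2 holds the lowest, and the only measured step, a 2.6-fold lower number from compound 1 to compound 2 (0.41 log units; beyond the scatter), lies beyond the scatter. Compound 3 `C/C(=C\C(=O)Nc1ccccc1OCCCC(=O)O)c1ccc2c(ccn2Cc2ccc(F)cc2)c1` has not yet been measured. It differs from compound 2 by fluoro in place of trifluoromethyl on an aromatic carbon; read one bond further out, 4-(trifluoromethyl)phenyl becomes 4-fluorophenyl. Among the compounds with values here, no measured step changes a group on this benzyl ring itself. Within the data shown here, the one step at hand, a 2.6-fold lower number from compound 1 to compound 2 (0.41 log units; beyond the scatter), shows that the whole 4-(trifluoromethyl)benzyl group in place of hydrogen brought a modest gain, but it does not separate the share of the trifluoromethyl from that of the rest of the group. Compound 3 keeps the benzyl group and exchanges only trifluoromethyl for fluoro, so the expected step in this assay is a 1.3-fold higher number from compound 2 to compound 3 (0.12 log units; within the scatter), which would stay within the scatter. Compound 3 is therefore estimated at 400 nM in this assay, with a range from 180 nM to 900 nM.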

Compound 3, half-maximal inhibitory concentration: 97 nM
For compound 3 the middle estimate is 4.1-fold (0.62 log units) above the measured one; measured number below the stated range.
By their numbers in this assay, from the lowest: compound 3; then compound 2; then compound 1.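

In this assay the substituent on the benzyl ring proves to matter in its own right: fluoro in place of trifluoromethyl, on an aromatic carbon para to a large group, gives a 3.1-fold lower number from compound 2 to compound 3 (0.49 log units; beyond the scatter) and so a lower number with one heavy atom in place of four. The group on the aromatic nitrogen can therefore bring more than the first pair showed, since a 2.6-fold lower number from compound 1 to compound 2 (0.41 log units; beyond the scatter) for the 4-(trifluoromethyl)benzyl group is now exceeded by an 8.0-fold lower number from compound 1 to compound 3 (0.91 log units; beyond the scatter) for the 4-fluorobenzyl group, and compound 3 holds the lowest number of the three. No evidence is available to explain why the change from trifluoromethyl to fluoro lowers the number.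

With only two substituents compared on this ring, the compounds shown establish no trend across substituents, and the share of the benzyl group itself remains unresolved without the unsubstituted benzyl group. On these data alone, it also remains open how chloro, methoxy or a nitrile on the same aromatic carbon would compare with fluoro, and whether the gain from fluoro holds if the butanoic acid chain on the shared core is replaced by a shorter or longer carboxylic acid chain.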